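A Methyl on the Outer Ring of Compound 1

A few compounds are considered here, and "the series" means these few. Any claim that something is new, unique, unknown or untested is made for them only; others in the source may bear on it.

Of the compounds shown here, three have been measured so far.
Compound 1 `O=C(O)COc1ccc(NC(=O)COc2ccccc2)cc1F` gives 29.8%.
Compound 2 `CC(Oc1ccccc1)C(=O)Nc1ccc(OCC(=O)O)c(F)c1` gives 35.7%.
Compound 3 `CCOc1ccccc1OC(C)C(=O)Nc1ccc(OCC(=O)O)c(F)c1` gives 8.79%.

All three numbers come from a functional assay on CHO cells for agonist activity at Free fatty acid receptor 1 (Homo sapiens), read by FLIPR, tested at 100 nM; on this read-out lower numbers stand for a weaker effect and higher numbers for a stronger effect at the one concentration tested. Compound 1 holds the second highest of the three values; its nearest neighbour is compound 2, with a number 5.9 percentage points higher from compound 1 to compound 2 (within the scatter), while compound 3 gave the lowest number of the set, and this gap is beyond the scatter.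

The next compound, compound 4 `Cc1cccc(OCC(=O)Nc2ccc(OCC(=O)O)c(F)c2)c1`, differs from compound 1 in one place: methyl in place of hydrogen on an aromatic carbon. Within the data shown here, two measured steps bear on this. The first also adds a methyl, but on a saturated chain carbon rather than on an aromatic carbon: a number 5.9 percentage points higher from compound 1 to compound 2 (within the scatter). The second adds a group to an aromatic carbon, though a larger one, ethoxy: a number 26.9 percentage points lower from compound 2 to compound 3 (beyond the scatter). A methyl on an aromatic carbon sits between these cases, being a ring substituent but a small one, so only a small step is expected for compound 4, most likely none beyond the scatter and, if anything, towards lower numbers.

Compound 4 is therefore estimated at 26%, with a range from 12% to 40%, which means an expected a number 3.8 percentage points lower from compound 1 to compound 4 (within the scatter).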

Compound 4, a percentage reported as activity, at one concentration (the size of the read-out at that concentration, not a potency): 45.4%
The estimate for compound 4 lay 19.4 percentage points below the measured number; the whole stated range lies below it.
By their numbers in this assay, from the lowest: compound 3; then compounds 1, 2 and 4 (each within the scatter of the next, the first and the last beyond it).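

Adding a single methyl to the outer ring, which turns phenoxy into 3-methylphenoxy, gave a number 15.6 percentage points higher from compound 1 to compound 4 (beyond the scatter) in this assay, so this aromatic carbon accepts a small group and the read-out can rise when it is filled. The earlier methyl on the chain carbon gave a number 5.9 percentage points higher from compound 1 to compound 2 (within the scatter), and the ethoxy on an aromatic carbon gave a number 26.9 percentage points lower from compound 2 to compound 3 (beyond the scatter), so compound 4 shows that adding a group to the outer ring does not always lower the number, even though compound 3 went that way from a different starting compound and with a larger group. Nothing available here explains the rise in compound 4.

Going by these compounds, it remains open whether the rise is specific to methyl or would also appear with a chlorine atom, a methoxy group or an ethyl group on the same carbon. Also open, on these data alone, are what a methyl does on the other carbons of the outer ring, and whether this ring methyl and the chain methyl of compound 2 would add up when placed together in one molecule.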